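Series notes: replacing the nitro group of compound 1

A few compounds are considered here, and "the series" means these few. Any claim that something is new, unique, unknown or untested is made for them only; others in the source may bear on it.

Compound 1 `COc1cc(OC)c(/C=C/S(=O)(=O)Cc2ccc(OC)c([N+](=O)[O-])c2)c(OC)c1` in a functional assay on DU-145 cells (Homo sapiens) for cytotoxicity, read by trypan blue exclusion, with a stated time of 96 h (on this read-out lower numbers stand for stronger inhibition and higher numbers for weaker inhibition), gives 2500 nM, the lowest of the three numbers in hand. Compound 2 `COc1ccc(CS(=O)(=O)/C=C/c2c(OC)cc(O)cc2OC)cc1[N+](=O)[O-]` gives 5000 nM in this assay, and compound 3 `COc1cc(OC)c(/C=C/S(=O)(=O)Cc2ccc(Br)c([N+](=O)[O-])c2)c(OC)c1` gives 25000 nM. The step of a 2.0-fold higher number from compound 1 to compound 2 (0.30 log units; within the scatter) leaves compounds 1 and 2 unordered, while the step of a 10-fold higher number from compound 1 to compound 3 (1.00 log units; beyond the scatter) sets compound 3 furthest from compound 1.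

Compound 4 `COc1cc(OC)c(/C=C/S(=O)(=O)Cc2ccc(OC)c(NC(F)(F)C(=O)O)c2)c(OC)c1` differs from compound 1 by (carboxy(difluoro)methyl)amino in place of nitro on an aromatic carbon. Going by the values given here, no measured step touches the nitro group itself. Among the compounds with values here, the only change measured on the ring that carries it, from compound 1 to compound 3, cost a 10-fold higher number from compound 1 to compound 3 (1.00 log units; beyond the scatter), and the change on the other ring, from compound 1 to compound 2, stayed within the scatter. A larger and more polar-looking replacement than either measured change is therefore expected to move the number upward beyond the scatter, estimated at a 6.0-fold higher number from compound 1 to compound 4 (0.78 log units; beyond the scatter). Compound 4 in this assay is estimated at 15000 nM, with a range from 4000 nM to 60000 nM.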

Compound 4, half-maximal inhibitory concentration: 150 nM
Compound 4: the middle estimate sits 100-fold (2.00 log units) above what was measured; measured number outside the range, below it.
By their numbers in this assay, from the lowest: compound 4; then compounds 1 and 2 (each within the scatter of the next); then compound 3.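

Going by these compounds alone, the nitro group is not required for activity at this position in this assay, since (carboxy(difluoro)methyl)amino on this aromatic carbon, ortho to a methoxy group, gives a 17-fold lower number from compound 1 to compound 4 (1.22 log units; beyond the scatter) and is the largest step so far. The earlier change on this ring, a 10-fold higher number from compound 1 to compound 3 (1.00 log units; beyond the scatter), ran the other way, so this ring can move the number in both directions, and a group of 7 heavy atoms with 2 hydrogen-bond donors is tolerated where nitro, with 3 heavy atoms and 0 donors, stood. No measurement in hand explains the size or direction of this step.

Which part of the new group carries the step stays open: a plain amine, or a carboxylic acid chain without the two fluorines, would separate these parts. Also open, from the compounds shown here alone, is whether the same replacement holds up alongside the hydroxy group of compound 2 or the bromo group of compound 3.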